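The source may report more compounds than this note shows. Statements on the series, on what has been measured and on what is new or still open speak of the compounds shown alone.

Within the data shown here, compound 2 `CN(C)CCn1cnnc1-c1cc(Oc2ccc(NC(=O)N/N=C/c3ccccc3O[N+](=O)[O-])cc2F)ccn1` holds the highest of the two numbers so far in a functional assay on MKN-45 cells (Homo sapiens) for cytotoxicity, read by MTT assay, with a stated time of 72 h (a lower number here means a stronger inhibitor, a higher number a weaker inhibitor), though its nearest neighbour, compound 1 `CN(C)CCn1cnnc1-c1cc(Oc2ccc(NC(=O)N/N=C/c3c[nH]c4ccccc34)cc2F)ccn1`, lies within the scatter of it. In this assay compound 1 gives 790 nM. In this assay compound 2 gives 1020 nM. Compound 3 `CN(C)CCn1cnnc1-c1cc(Oc2ccc(NC(=O)N/N=C/c3ccc(O)c(F)c3)cc2F)ccn1` differs from compound 2 in one place: 3-fluoro-4-hydroxyphenyl in place of 2-(nitrooxy)phenyl on a carbon with a double bond to nitrogen. Among the measured compounds shown here, the only measured step bearing on this position is a 1.3-fold higher number from compound 1 to compound 2 (0.11 log units; within the scatter), and it did not move the number beyond the scatter. Since the aryl group on the same carbon has so far been swapped without a clear shift, no step beyond the scatter is expected in this assay for the change to compound 3 either. The estimated step is a 1.1-fold lower number from compound 2 to compound 3 (0.05 log units; within the scatter). For the measured compounds named here, compound 3 is therefore expected near 900 nM, with a range from 350 nM to 2500 nM, the width reflecting that only one prior swap at this site is known.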

Compound 3, half-maximal inhibitory concentration: 1970 nM
Estimate against measurement, compound 3: 2.2-fold (0.34 log units) below; measured number inside the range.
By their numbers in this assay, from the lowest: compounds 1, 2 and 3 (each within the scatter of the next, the first and the last beyond it).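

In this assay, the aryl group on the carbon with a double bond to nitrogen now gives its first step beyond the scatter, a modest one: a 2.5-fold higher number from compound 1 to compound 3 (0.40 log units; beyond the scatter), with 3-fluoro-4-hydroxyphenyl in place of 1H-indol-3-yl. The other new step, a 1.9-fold higher number from compound 2 to compound 3 (0.29 log units; within the scatter), stays within the scatter, so 3-fluoro-4-hydroxyphenyl and 2-(nitrooxy)phenyl are not separated here, and only the two ends of the three-compound order differ beyond the scatter. Nothing measured on these compounds speaks to what lies behind the step.

Open, on these data alone, is whether the step away from 1H-indol-3-yl follows the fluorine, the hydroxyl or the two together. Also open, as far as these compounds go, is how a phenyl ring carrying an amine or a carboxylic acid would read on this carbon in this assay.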